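Trifluoromethyl to Difluoromethyl on the Piperidine Amide

The compounds below may be only part of what the source reports. "The series", "measured", "known", "first", "only" and "open" are said of these compounds alone.

Compound 2 `CCN(CC)S(=O)(=O)c1ccc(S(=O)(=O)N2CCC[C@@H](C(=O)N3CCC(C(F)(F)F)CC3)C2)cc1` gives 370 nM in a functional assay on BXPC-3 cells (Homo sapiens) for inhibition, read by MTT assay, with a stated time of 7 days (on this read-out higher numbers stand for weaker inhibition and lower numbers for stronger inhibition), the second highest of the three numbers measured. Compound 3 `O=C([C@@H]1CCCN(S(=O)(=O)c2ccc(S(=O)(=O)N3CC[C@H](O)C3)cc2)C1)N1CCC(F)(F)CC1` gives 580 nM, which lies within the scatter of compound 2, while compound 1 `CCC(CC)S(=O)(=O)c1ccc(S(=O)(=O)N2CCC[C@@H](C(=O)N3CCC(F)(F)CC3)C2)cc1` gives 40 nM, beyond the scatter and lower than both. Within the data shown here, the only single-place step among the measured compounds, a 15-fold higher number from compound 1 to compound 3 (1.16 log units; beyond the scatter), concerns a group on a sulfonyl sulfur and says nothing about the amide side of the molecule. Compound 4 `CCN(CC)S(=O)(=O)c1ccc(S(=O)(=O)N2CCC[C@@H](C(=O)N3CCC(C(F)F)CC3)C2)cc1` differs from compound 2 by hydrogen in place of fluoro on a saturated chain carbon bound to two fluorine atoms and a saturated ring carbon. Among the measured compounds shown here, no measured step bears on this change, so the expectation rests on compound 2 alone, and no step beyond the scatter is expected. Compound 4 is therefore estimated at 370 nM, with a range from 150 nM to 900 nM. The expected step is no change at the digits printed from compound 2 to compound 4 (within the scatter).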

Compound 4, half-maximal inhibitory concentration: 450 nM
Compound 4: the middle estimate sits 1.2-fold (0.09 log units) below what was measured; measured number inside the range.
By their numbers in this assay, from the lowest: compound 1; then compounds 2, 4 and 3 (each within the scatter of the next).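

Replacing 4-(trifluoromethyl)piperidin-1-yl with 4-(difluoromethyl)piperidin-1-yl gives a 1.2-fold higher number from compound 2 to compound 4 (0.09 log units; within the scatter) in this assay, so here one fluoro can give way to hydrogen without a change that can be told from the scatter. This is the first single-place step shown on the amide side of the molecule. Nothing available explains this result. Still open, from the compounds shown here alone, is how a fluoromethyl, methyl or hydroxymethyl group would read at this place, with the rest of the molecule kept the same.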